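Amino for Hydrogen on a Purine-Type Core: Expected Cytotoxicity

This account rests on a few compounds, and the source may have more. Where it says the series, first, only, none or still open, it means among the compounds named here.

The account concerns two measured compounds and one that is not yet measured, all read in a functional assay on SK-MEL-2 cells (Homo sapiens) for cytotoxicity, read by sulforhodamine B assay, with a stated time of 48 h; on this read-out higher numbers stand for lower toxicity in this test and lower numbers for higher toxicity in this test. Compound 1 `ClCc1ccc(Cn2cnc3c(Cl)ncnc32)cc1` is the reference point. In this assay compound 1 gives > 100000 nM, which is a limit of the assay rather than a number; compound 1 therefore stands at the less toxic end of what has been seen, as the limit of > 100000 nM in this assay, at which 1 of the 2 values shown sits, records. Among the compounds with values here, compound 2 `ClCc1cccc(Cn2cnc3c(Cl)nc(Cl)nc32)c1` differs from compound 1 in more than one place, so no single step links them; in this assay compound 2 gives 10000 nM.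

Compound 3 `Nc1nc(Cl)c2ncn(Cc3ccc(CCl)cc3)c2n1` is the next compound to be measured. It differs from compound 1 by amino in place of hydrogen on an aromatic carbon. Within the data shown here, no measured step between compounds exists to set the size of this change, so the expectation can rest only on the standing of compound 1 itself. Compound 3 is expected to remain in the same region as compound 1, with the step from compound 1 to compound 3 estimated as a number no higher from compound 1 to compound 3 (the limit leaves the size open), which lies within the scatter. Compound 3 is therefore estimated at 100000 nM, with a range from 30000 nM to 300000 nM, and a fair chance that the assay again reports only a limit.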

Compound 3, concentration lethal to 50% of the cells: 74100 nM
Estimate against measurement, compound 3: 1.3-fold (0.13 log units) above, within the range that was stated.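

In this assay the change of amino in place of hydrogen on an aromatic carbon, at the carbon between two ring nitrogen atoms, now has its first step: an at least 1.3-fold lower number from compound 1 to compound 3 (0.13 log units; that floor lies within the scatter). At this position, with amino present, compound 3 gives 74100 nM, a number that lies inside the reach of the assay, so the series now has a value at this place that can serve as a base for later steps. The true size of the step nevertheless stays open, because the starting point in compound 1 is a limit of the assay and not a number: the limit of > 100000 nM in this assay, at which 1 of the 3 values shown sits.

The compounds shown leave open whether a methylamino group, a hydroxyl group or a longer chain on the same carbon would read alike in this assay. They also leave open whether amino in place of hydrogen at this position would give a step of measurable size on a compound whose own value is a number rather than a limit.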